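Swapping Phenoxy for Methoxy on Compound 3

The source may hold more compounds than are shown below. What is called first, only, known or untested is meant among the compounds shown, and "the series" means these compounds.

Measured compounds:
compound 1, `Fc1ccc(C2=CC3CNCC(C2)C3)cn1`: 28 nM
compound 2, `COc1ccc(C2=CC3CC(C2)CN(C)C3)cn1`: > 10000 nM
compound 3, `C1=C(c2cncc(Oc3ccccc3)c2)CC2CNCC1C2`: 1.9 nM

In an in vitro assay on SH-SY5Y cells for displacement of a labelled ligand from Neuronal acetylcholine receptor; alpha3/beta4 (Homo sapiens) (on this read-out higher numbers stand for weaker inhibition and lower numbers for stronger inhibition), compound 3 gives 1.9 nM, the lowest of the two numbers shown, while compound 1 gives 28 nM, a gap that lies beyond the usual scatter. For compound 2 the reported result > 10000 nM is a limit of this assay rather than a number, as noted in the limit of > 10000 nM in this assay, at which 1 of the 3 values shown sits. Compound 4, `COc1cncc(C2=CC3CNCC(C2)C3)c1`, differs from compound 3 by methyl in place of phenyl on an oxygen on an aromatic ring. Going by the values given here, no pair of measured compounds differs in exactly this place, so the size of the step cannot be read from the data. Compound 4 is expected to bind more weakly than compound 3, with an estimated step of a 16-fold higher number from compound 3 to compound 4 (1.20 log units; beyond the scatter) beyond the scatter. The estimate for compound 4 is 30 nM, between 8 nM and 150 nM.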

Compound 4, inhibition constant: 14.3 nM
Compound 4: the middle estimate sits 2.1-fold (0.32 log units) above what was measured; the measured number falls inside the stated range.
By their numbers in this assay, from the lowest: compound 3; then compounds 4 and 1 (each within the scatter of the next). At a limit, above all of these: compound 2.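

Going by these compounds alone, this is the first direct reading of a change at this oxygen: in this assay, swapping phenoxy for methoxy gives a 7.5-fold higher number from compound 3 to compound 4 (0.88 log units; beyond the scatter). The phenyl group therefore counts for something here, yet binding does not vanish without it, since compound 4 still gives a measured 14.3 nM. Nothing available explains the size of this step.

Still open, going by these compounds, is whether an ethyl or benzyl group on this oxygen would land nearer compound 3 or compound 4. The effect of an amine in place of the oxygen is open as well.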